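The source may hold more compounds than are shown below. What is called first, only, known or untested is meant among the compounds shown, and "the series" means these compounds.

Compounds measured so far in a toxicity assay on Huh-7 cells (Homo sapiens) for cytotoxicity, read by CCK-8 assay, with a stated time of 24 h; on this read-out lower numbers stand for higher toxicity in this test and higher numbers for lower toxicity in this test:

Compound 1 `O=c1cc(-c2ccccc2)oc2c(-c3ccc(F)cc3)c(O)c(O)c(O)c12` reaches only a limit there, > 100000 nM. Compound 2 `Oc1c(O)c(O)c2c(=S)cc(-c3ccccc3)oc2c1-c1cccc(F)c1` likewise sits at a limit, > 100000 nM. Compound 3 `COc1cc2oc(-c3ccc(Nc4ccc(F)cc4)cc3)cc(=O)c2c(OC)c1OC` returns a number, 77600 nM.

Compound 2 thus stands at the edge of what this assay reports: for it only a limit is known, and one further value among the three is also a limit, so compound 2 shares with compound 1 (the limit of > 100000 nM in this assay, at which 2 of the 3 values shown sit), while compound 3 alone gives a number. With only a range known for compound 2, no order between compound 2 and compound 3 can be stated.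

The step to compound 4 `Oc1cc2oc(-c3ccccc3)cc(=S)c2c(O)c1O` puts, on the core of compound 2, (hydrogen in place of 3-fluorophenyl on an aromatic carbon). Within the data shown here, no measured pair in the set differs in a single place, so no step of this kind has been observed. The step from compound 2 to compound 4, a number no higher from compound 2 to compound 4 (the limit leaves the size open), is expected to be none beyond the scatter. Compound 4 is expected to give 100000 nM, ranging from 30000 nM to 300000 nM, most likely again as a limit.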

Compound 4, half-maximal cytotoxic concentration: > 100000 nM
Compound 4: no number, only a limit; the forecaster's own chance of this, stated with the estimate: 75%; the middle value sits exactly at the limit.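

In this assay no step can be read between compound 2 and compound 4, as both stand only at a limit: the limit of > 100000 nM in this assay, at which 3 of the 4 values shown sit.

The compounds shown leave open whether hydrogen in place of 3-fluorophenyl on an aromatic carbon changes the toxicity of compound 2 at all.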